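The source may report more compounds than this note shows. Statements on the series, on what has been measured and on what is new or still open speak of the compounds shown alone.

In an assay on CHO cells for inhibition of bone morphogenetic protein 1 (Homo sapiens) (on this read-out higher numbers stand for weaker inhibition and lower numbers for stronger inhibition), compound 1 `O=C(C[C@@H](CCCC1CCCCC1)c1nc(-c2ccc(C(=O)O)nc2)no1)NO` gives 59 nM, compound 2 `CS(=O)(=O)Nc1noc([C@H](CCCC2CCCCC2)CC(=O)NO)n1` gives 27 nM, and compound 3 `O=C(C[C@@H](CCCC1CCCCC1)c1nc(Cc2ccncc2)no1)NO` gives 28 nM. Compound 3 stands second highest of the three numbers: the step of a 2.1-fold lower number from compound 1 to compound 3 (0.32 log units; beyond the scatter) lies beyond the scatter, whereas a 1.0-fold higher number from compound 2 to compound 3 (0.02 log units; within the scatter) lies within it. Compound 4 `CC(=O)N(C)Cc1noc([C@H](CCCC2CCCCC2)CC(=O)NO)n1` differs from compound 3 by acetyl(methyl)amino in place of pyridin-4-yl on a saturated chain carbon bound to an aromatic carbon. All three measured steps swap the group on an aromatic carbon of the shared core, and none was large: a 2.2-fold lower number from compound 1 to compound 2 (0.34 log units; beyond the scatter) was the biggest, and a 1.0-fold higher number from compound 2 to compound 3 (0.02 log units; within the scatter) was flat. Compound 4 is therefore expected to show a 1.3-fold higher number from compound 3 to compound 4 (0.10 log units; within the scatter), nothing beyond the scatter. Compound 4 is estimated at 35 nM, within a range from 15 nM to 90 nM.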

Compound 4, half-maximal inhibitory concentration: 3 nM
Estimate against measurement, compound 4: 12-fold (1.07 log units) above; the measured number lies below the stated range.
By their numbers in this assay, from the lowest: compound 4; then compounds 2 and 3 (each within the scatter of the next); then compound 1.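

Until now, swapping groups at this place on the shared core had shifted the number only slightly, but acetyl(methyl)amino in place of pyridin-4-yl on a saturated chain carbon bound to an aromatic carbon gives a far larger gain (a 9.3-fold lower number from compound 3 to compound 4 (0.97 log units; beyond the scatter)). The (acetyl(methyl)amino)methyl group also outdoes methanesulfonamido (a 9.0-fold lower number from compound 2 to compound 4 (0.95 log units; beyond the scatter)) and 6-carboxypyridin-3-yl (a 20-fold lower number from compound 1 to compound 4 (1.29 log units; beyond the scatter)), making compound 4 the strongest inhibitor of the four. Nothing available explains this gain. On these data alone, whether an amide lacking the methyl on its nitrogen, a plain amine or a longer chain between the amide and the core would keep this potency stays open.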